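Furan analogue of a bis-hydroxyphenyl pyridine

The source may hold more compounds than are shown below. What is called first, only, known or untested is meant among the compounds shown, and "the series" means these compounds.

The series is built on a shared core carrying two hydroxyphenyl groups and a five-membered heteroaryl ring. Compound 1 `Oc1cccc(-c2cc(-c3ccsc3)cc(-c3cccc(O)c3)n2)c1` bears a thiophene ring alongside two 3-hydroxyphenyl groups and in a functional assay on HCT-15 cells (Homo sapiens) for cytotoxicity, read by CCK-8 assay (a lower number here means a stronger inhibitor, a higher number a weaker inhibitor), compound 1 gives 1630 nM. Compound 2 `Oc1cccc(-c2cc(-c3ccoc3)cc(-c3ccccc3O)n2)c1` replaces the thiophene with a furan and carries one 2-hydroxyphenyl group in place of a 3-hydroxyphenyl group. In this assay compound 2 reaches only the limit of the assay at > 50000 nM, so no number is known for it, as noted in the limit of > 50000 nM in this assay, at which 1 of the 2 values shown sits.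

Compound 3 `Oc1cccc(-c2cc(-c3ccoc3)cc(-c3cccc(O)c3)n2)c1` differs from compound 2 by 3-hydroxyphenyl in place of 2-hydroxyphenyl on an aromatic carbon. Among the compounds with values here, no measured step between two compounds isolates this change, so the expectation rests on the two values at hand. Compound 3 is expected to move well beyond the scatter toward stronger inhibition, with an at least 16-fold lower number from compound 2 to compound 3 (1.22 log units; beyond the scatter), because compound 1 with the same two 3-hydroxyphenyl groups gives 1630 nM. The estimate for compound 3 in this assay is 3000 nM, expected to fall between 800 nM and 15000 nM.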

Compound 3, half-maximal inhibitory concentration: 1020 nM
Compound 3: middle estimate off by 2.9-fold (0.47 log units), on the high side; the measured number falls inside the stated range.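

In this assay, 3-hydroxyphenyl in place of 2-hydroxyphenyl on an aromatic carbon next to the ring nitrogen gives an at least 49-fold lower number from compound 2 to compound 3 (1.69 log units; beyond the scatter), so at this position the two groups are sharply told apart even though they hold the same atoms. Compound 2 stands only at a limit of the assay, so the full size of that step is not known: the limit of > 50000 nM in this assay, at which 1 of the 3 values shown sits. The five-membered ring shows no such separation, since furan-3-yl in place of thiophen-3-yl gives a 1.6-fold lower number from compound 1 to compound 3 (0.20 log units; within the scatter), and with two 3-hydroxyphenyl groups on the shared core the furan and the thiophene cannot be told apart here.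

The compounds shown leave open whether the sharp step belongs to 2-hydroxyphenyl alone or whether 4-hydroxyphenyl or a methoxyphenyl group at this place would behave the same way. They also leave open whether the other 3-hydroxyphenyl group, which all three compounds carry, could give way to a plain phenyl or an aminophenyl group without a step beyond the scatter.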